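The source may report more compounds than this note shows. Statements on the series, on what has been measured and on what is new or still open speak of the compounds shown alone.

Compound 1 `CNC1=C(Sc2ccccc2)C(=O)c2ncccc2C1=O` and compound 2 `CNC1=C([S+](C)[O-])C(=O)c2ncccc2C1=O` share one core, while compound 3 `CNC1=C(Sc2ccccc2)C(=O)c2cccnc2C1=O` and compound 4 `CNC1=C([S+](C)[O-])C(=O)c2cccnc2C1=O` share a second core built from the same atoms joined differently; the difference between the two cores is not broken down here. All three measured compounds were tested in a functional assay on HL-60 cells (Homo sapiens) for antiproliferative activity, read by MTT assay, with a stated time of 48 h; a higher number here means a weaker inhibitor, a lower number a stronger inhibitor. In this assay compound 1 gives 8030 nM, and compound 2 gives 12100 nM in this assay. The change between them is a group of 3 heavy atoms (1 carbon, 1 oxygen, 1 sulfur; no ring) in place of a group of 7 heavy atoms (6 carbon, 1 sulfur; one six-membered aromatic ring of carbon only), on a double-bonded ring carbon, and it made a step of a 1.5-fold higher number from compound 1 to compound 2 (0.18 log units; within the scatter). In this assay compound 3 gives 5880 nM, a number that lies within the scatter of the number for compound 1; compound 2 gives a higher number than compound 3, and that gap lies beyond the scatter.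

Compound 4 carries the same change on the second core, namely (a group of 3 heavy atoms (1 carbon, 1 oxygen, 1 sulfur; no ring) in place of a group of 7 heavy atoms (6 carbon, 1 sulfur; one six-membered aromatic ring of carbon only), on a double-bonded ring carbon). The place of the change is described in the same words for both pairs, so it is taken as the same change. Within the data shown here, the only guide for its size is the measured pair, because a 1.5-fold higher number from compound 1 to compound 2 (0.18 log units; within the scatter) shows a step that stays within the scatter. A step of about that size is therefore expected here as well. Compound 4 is expected to give about 8800 nM in this assay. The expected range for compound 4 runs from 4000 nM to 20000 nM. This estimate means an expected step of a 1.5-fold higher number from compound 3 to compound 4 (0.18 log units; within the scatter).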

Compound 4, half-maximal inhibitory concentration: 33200 nM
The estimate for compound 4 lay 3.8-fold (0.58 log units) below the measured number, outside the stated range (above it).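

In this assay, putting the group of 3 heavy atoms in place of phenylsulfanyl on the double-bonded ring carbon gave a step of a 5.6-fold higher number from compound 3 to compound 4 (0.75 log units; beyond the scatter), which is a clear loss of activity on this core. The same change therefore did not carry over at one size from the core of compound 1 to the core of compound 3, and the two steps have to be read as different: the same change on two cores in this assay, a 1.5-fold higher number (0.18 log units; within the scatter) from compound 1 to compound 2 and a 5.6-fold higher number (0.75 log units; beyond the scatter) from compound 3 to compound 4, 3.7-fold (0.57 log units) apart, beyond the scatter of two such steps. This shows that the effect of the change in this series depends on the core it sits on, so a step measured on one core was a poor guide to the other, but with a single pair on each core it shows neither why the cores differ nor how far this holds for any other change.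

The compounds shown leave open whether other groups on that double-bonded ring carbon, such as a methylsulfanyl group, a benzylsulfanyl group or an amine, would also give steps that differ between the two cores. They also leave open whether the gap between the steps would persist if the methylamino group gave way to a longer chain.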